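The compounds below may be only part of what the source reports. "The series", "measured", "known", "first", "only" and "open" are said of these compounds alone.

Measured in a functional assay on CNE-2 cells (Homo sapiens) for inhibition, read by MTT assay, with a stated time of 72 h; a lower number here means a stronger inhibitor, a higher number a weaker inhibitor:
- Compound 1 `Nc1ncnc2c1c(-c1cnc3[nH]ccc3c1)nn2CCCCC(=O)NO`: > 150000 nM, a limit of the assay and not a number
- Compound 2 `Nc1nc2cc(-c3nn(CCCCCCCCCC(=O)NO)c4ncnc(N)c34)ccc2o1`: 36800 nM
- Compound 3 `Nc1ncnc2c1c(-c1cnc3[nH]ccc3c1)nn2CCCCCCCCCC(=O)NO`: 2200 nM

Compound 1 gives no number on this scale, only (the limit of > 150000 nM in this assay, at which 1 of the 3 values shown sits). Compound 4 `Nc1ncnc2c1c(-c1cnc3[nH]ccc3c1)nn2CCC(=O)NO` keeps the core of compound 1 and differs from it in the chain: hydroxycarbamoyl in place of 2-(hydroxycarbamoyl)ethyl on a saturated chain carbon, two bonds along the chain from an aromatic nitrogen. Here hydroxycarbamoyl takes the place of 2-(hydroxycarbamoyl)ethyl on a saturated chain carbon, two bonds along the chain from an aromatic nitrogen.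

The closest evidence is a change in the same chain, in the opposite sense, where 5-(hydroxycarbamoyl)pentyl replaces hydroxycarbamoyl: an at least 68-fold lower number from compound 1 to compound 3 (1.83 log units; beyond the scatter). The other measured step, a 17-fold lower number from compound 2 to compound 3 (1.22 log units; beyond the scatter), concerns a different part of the molecule and does not bear on this change. A shorter chain is therefore expected to move this assay towards a higher number, if at all, though the limit hides the size of any such move. The expected outcome is a step that the limit leaves unreadable from compound 1 to compound 4. For compound 4 the estimate is 200000 nM, with an expected range of 80000 nM to 500000 nM.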

Compound 4, half-maximal inhibitory concentration: > 150000 nM
Compound 4: no number, only a limit; the forecaster's own chance of this, stated with the estimate: 80%; the middle value does not contradict the limit.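

In this assay compound 4, like compound 1, gives a limit of the assay and not a number, so no step can be read between the two: the limit of > 150000 nM in this assay, at which 2 of the 4 values shown sit.

The compounds shown leave open whether compound 1 and compound 4 differ at all in this assay, and at which chain length up to that of compound 3 the number begins to fall.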